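A smaller group on compound 2: what to expect for compound 3

The source may report more compounds than this note shows. Statements on the series, on what has been measured and on what is new or still open speak of the compounds shown alone.

Measured so far:
compound 1, `Nc1ccccc1NC(=O)/C=C/c1ccc(Cn2cnc3c(NCc4ccccc4)nc(Cl)nc32)cc1`, 17.4%
compound 2, `Nc1ccccc1NC(=O)c1ccc(Cn2cnc3c(Nc4ccc(-c5ccccn5)cc4)nc(Cl)nc32)cc1`, 73.7%

Both were tested in a functional assay on HCT-116 cells (Homo sapiens) for antiproliferative activity, read by CCK-8 assay, with a stated time of 72 h, tested at 8 uM; on this read-out lower numbers stand for a weaker effect and higher numbers for a stronger effect at the one concentration tested. Among the two numbers compound 2 stands highest, with compound 1 as its only neighbour, a number lower by a margin beyond the usual scatter. Within the data shown here, compound 1 and compound 2 differ in more than one place, so no single step between measured compounds is available; their two values show only that compound 2 reaches much the higher inhibition.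

Compound 3, `Cc1ccc(Nc2nc(Cl)nc3c2ncn3Cc2ccc(C(=O)Nc3ccccc3N)cc2)cc1`, has not yet been measured. It differs from compound 2 in one place: methyl in place of pyridin-2-yl on an aromatic carbon. Among the measured compounds shown here, the group that leaves is far larger than the group that enters, and nothing among the measured compounds isolates this change. For the measured compounds named here, a moderate fall is expected rather than none, because compound 2 gives 73.7% while its only neighbour sits far below it, so the room for a drop is wide. The step of a number 18.7 percentage points lower from compound 2 to compound 3 (beyond the scatter) is the expected change. Compound 3 is estimated at 55%, within a range from 30% to 78%.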

Compound 3, a percentage reported as inhibition, at one concentration (the size of the read-out at that concentration, not a potency): 81.5%
The estimate for compound 3 lay 26.5 percentage points below the measured number; measured number above the stated range.
By their numbers in this assay, from the lowest: compound 1; then compounds 2 and 3 (each within the scatter of the next).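

In this assay, putting methyl in place of pyridin-2-yl gives a number 7.8 percentage points higher from compound 2 to compound 3 (within the scatter), so this assay does not distinguish the two groups at this carbon, para to a large group. The earlier compounds shown here could not show this: at this one concentration, the change from 4-(pyridin-2-yl)phenyl to 4-methylphenyl gives up a whole six-membered aromatic ring and its hydrogen-bond acceptor without a difference beyond the scatter, so neither is required to retain inhibition here. No available measurement accounts for this result.

The compounds shown leave open whether a bare hydrogen, a chlorine, a methoxy group, an amine or a carboxylic acid on the same carbon would retain the inhibition. Because each compound was read at a single concentration, they also leave open whether compound 2 and compound 3 match in potency.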